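Swapping the Five-Membered Ring: From Compound 1 to Compound 3

The compounds below may be only part of what the source reports. "The series", "measured", "known", "first", "only" and "open" are said of these compounds alone.

Of the compounds shown here, two sharing one core have so far been measured in an assay on isolated protein for inhibition of Amine oxidase [flavin-containing] A (Homo sapiens), read by fluorescence; a higher number here means a weaker inhibitor, a lower number a stronger inhibitor. Compound 1 `O=C(/C=C/c1ccsc1)c1cc(O)c(O)c([N+](=O)[O-])c1` gives 41400 nM in this assay. Compound 2 `N#Cc1cccc(/C=C/C(=O)c2cc(O)c(O)c([N+](=O)[O-])c2)c1` gives 58900 nM in this assay. These two numbers lie within the usual scatter of each other, so neither compound can be set apart from the other, and both are weak inhibitors; compound 1 simply serves as the starting point here.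

Compound 3 `Cn1cc(/C=C/C(=O)c2cc(O)c(O)c([N+](=O)[O-])c2)cn1` differs from compound 1 in a single place: 1-methyl-1H-pyrazol-4-yl in place of thiophen-3-yl on a double-bonded chain carbon bound to a double-bonded chain carbon. Going by the values given here, no measured pair shows what such a swap does to the readout. Among the compounds with values here, the only comparison on hand, compound 1 against compound 2, shows two values that cannot be told apart, which offers no sign that changing the ring at this end of the chain moves the number much. The author therefore expects the step of a 1.2-fold higher number from compound 1 to compound 3 (0.08 log units; within the scatter) to be small, most likely none beyond the scatter, with a slight lean toward a higher number. For compound 3 the estimated value is 50000 nM, with an expected range from 20000 nM to 130000 nM.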

Compound 3, half-maximal inhibitory concentration: 51500 nM
Estimate against measurement, compound 3: 1.0-fold (0.01 log units) below, within the range that was stated.
By their numbers in this assay, from the lowest: compounds 1, 3 and 2 (each within the scatter of the next).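

Going by these compounds alone, this is the first single-place step measured at this end of the chain: in this assay, 1-methyl-1H-pyrazol-4-yl in place of thiophen-3-yl on a double-bonded chain carbon bound to a double-bonded chain carbon gives a 1.2-fold higher number from compound 1 to compound 3 (0.09 log units; within the scatter), and the two compounds cannot be told apart. The swap exchanges a five-membered aromatic ring holding sulfur as its 1 hetero atom for one holding 2 nitrogen hetero atoms and a methyl group, and it takes the hydrogen-bond acceptor count from 1 to 2, yet in this one pair the reading stays inside the scatter. Nothing at hand explains this result, so it stands as an observation only.

On these data alone, whether a primary amine or a carboxylic acid on the ring at this end of the chain, or a longer alkyl chain in place of the methyl group, would carry the number beyond the scatter remains open. All the compounds shown also share one core, so what an amide in place of the carbonyl would do is equally open.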